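Methyl on the pyrrole nitrogen: parallel step in two cores

The source may hold more compounds than are shown below. What is called first, only, known or untested is meant among the compounds shown, and "the series" means these compounds.

Of the compounds shown here, three have been measured in a functional assay on the whole organism (strain Wistar Albino) for inhibition, with Rattus norvegicus as the target, read by paw edema, with a stated time of 3 h, at a dose of 20 mg/kg; a lower number here means less inhibition, a higher number more inhibition at the dose given (going by the name of the read-out). Compound 1 `COc1ccc(Cl)c(-c2nnc3n2NC(c2ccc[nH]2)S3)c1` gives 18.4%. Compound 3 `COc1ccc(Cl)c(-c2nnc3n2NC(c2cccn2C)S3)c1` differs from compound 1 only by methyl in place of hydrogen on an aromatic nitrogen; compound 3 gives 18.5%, and the step of a number 0.1 percentage points higher from compound 1 to compound 3 (within the scatter). Compound 2 `COc1ccc(Cc2nnc3n2NC(c2ccc[nH]2)S3)cc1OC` gives 17.7% in this assay, a number within the scatter of the values of compound 1 and compound 3, so no order among the three is read from these data. How the core of compound 2 differs from the core of compound 1 is not broken down here.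

Compound 4 `COc1ccc(Cc2nnc3n2NC(c2cccn2C)S3)cc1OC` has not yet been measured in this assay. It differs from compound 2 by methyl in place of hydrogen on an aromatic nitrogen, the same change as from compound 1 to compound 3, at the same place, which occurs twice among the compounds shown.

Among the compounds with values here, the only measured instance of this change, a number 0.1 percentage points higher from compound 1 to compound 3 (within the scatter), moved the read-out by an amount within the scatter. On that single step the same behaviour is expected for the second core: the step from compound 2 to compound 4 is estimated at a number 0.1 percentage points higher from compound 2 to compound 4 (within the scatter). Accordingly compound 4 is expected to give about 17.8% in this assay, with a range from 12% to 24%. Within the data shown here, that range rests on the single step of a number 0.1 percentage points higher from compound 1 to compound 3 (within the scatter) and on the value of compound 2, 17.7%.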

Compound 4, a percentage reported as inhibition, in the whole organism at one dose (the size of the read-out at that dose, not a potency): 18.4%
Beside the measured number, compound 4's estimate is 0.6 percentage points below it; measured number inside the range.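

The change from 1H-pyrrol-2-yl to 1-methyl-1H-pyrrol-2-yl now has two readings in this assay: the earlier one is a number 0.1 percentage points higher from compound 1 to compound 3 (within the scatter), the new one is a number 0.7 percentage points higher from compound 2 to compound 4 (within the scatter), and the two do not differ: the same change on two cores in this assay, a number 0.1 percentage points higher (within the scatter) from compound 1 to compound 3 and a number 0.7 percentage points higher (within the scatter) from compound 2 to compound 4, 0.6 percentage points apart, within the scatter of two such steps

On the two cores shown, the change therefore carries over in the same way, as a step that stays within the scatter on each, and nothing here indicates that the core sets the size of the step. This does not show that the methyl has no effect or that a small effect of fixed size exists, since readings at a single dose and a single time cannot separate a small real step from none, and two cores are no basis for a rule covering the whole series.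

The compounds shown leave open whether a larger group on that aromatic nitrogen, such as a benzyl group or a longer alkyl chain, or a carboxylic acid carried on such a chain, would give a step beyond the scatter in this assay. They also leave open whether the two cores would still read alike with such a group in place.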